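Naphthalen-1-yl Replaces Thiophen-2-yl on the Aromatic Carbon

The source may hold more compounds than are shown below. What is called first, only, known or untested is meant among the compounds shown, and "the series" means these compounds.

Three compounds share one acid-bearing core and differ only in the aromatic unit carried on its ether oxygen. Compound 1 `O=C(O)CC1COc2cc(OCc3nnc(-c4ccccc4)s3)ccc21` and compound 2 `Cc1cc(COc2ccc3c(c2)OCC3CC(=O)O)nn1-c1ccccc1` carry one kind of unit each, and compound 3 `Cc1nc(-c2cccs2)sc1COc1ccc2c(c1)OCC2CC(=O)O` a third. In a functional assay on CHO cells for agonist activity at Free fatty acid receptor 1 (Homo sapiens), read by FLIPR and calcium flux, tested at 100 nM (a lower number here means a weaker effect, a higher number a stronger effect of the compound at the concentration tested), compound 1 gives 3.36%, compound 2 gives 0.98%, and compound 3 gives 35.2%. Compound 3 therefore stands highest of the three; its nearest neighbour is compound 1, and compound 2 lies furthest away, both gaps being beyond the usual scatter.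

Compound 4 `Cc1nc(-c2cccc3ccccc23)sc1COc1ccc2c(c1)OCC2CC(=O)O` differs from compound 3 in one place: naphthalen-1-yl in place of thiophen-2-yl on an aromatic carbon. Among the compounds with values here, no pair of measured compounds shows this exchange, so its effect in this assay has no direct precedent here. Since compound 3 already gives 35.2% in this assay, the step from compound 3 to compound 4 is expected to be modest and upward, a number 6.8 percentage points higher from compound 3 to compound 4 (within the scatter), though it may well stay within the scatter. Compound 4 is accordingly estimated at 42%, with a plausible range from 15% to 70%.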

Compound 4, a percentage reported as activity, at one concentration (the size of the read-out at that concentration, not a potency): 8.53%
For compound 4 the middle estimate is 33.5 percentage points above the measured one, outside the stated range (below it).
By their numbers in this assay, from the lowest: compounds 2, 1 and 4 (each within the scatter of the next); then compound 3.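

Within the data shown here, the exchange of thiophen-2-yl for naphthalen-1-yl gives the first comparison that changes one place only, and in this assay it produces a number 26.7 percentage points lower from compound 3 to compound 4 (beyond the scatter) at the aromatic carbon next to the ring nitrogen and the ring sulfur. The read-out at this concentration therefore depends strongly on which aromatic group this carbon carries, and an aromatic group here does not by itself preserve the activity seen with thiophen-2-yl. No measurement at hand accounts for this fall.

The compounds shown leave open whether the fall goes with the second ring of naphthalen-1-yl or with the loss of the ring sulfur of thiophen-2-yl. As far as these compounds go, a phenyl group on the same carbon would separate these two possibilities, and the read-out with naphthalen-2-yl there is equally open.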